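This account rests on a few compounds, and the source may have more. Where it says the series, first, only, none or still open, it means among the compounds named here.

The series turns on a shared core carrying an amine nitrogen whose substituent is varied. Compound 1 is `CCC(=O)N[C@@H]1CCCc2c1cncc2N1CCc2cc(Cl)ccc2C1=O`. In an ADME assay on microsomes from liver (Homo sapiens) for metabolic stability, read by LC-MS, using NADPH, with stated times of 10 min and 30 min (on this read-out higher numbers stand for fast clearance and lower numbers for slow clearance), compound 1 gives < 3.5 mL/min/kg, which is a limit of the assay and not a number. Compound 2 is `CS(=O)(=O)N[C@@H]1CCCc2c1cncc2N1CCc2cc(Cl)ccc2C1=O`, and the change from compound 1 is methylsulfonyl in place of propanoyl on an amine nitrogen. In this assay compound 2 gives < 3.5 mL/min/kg, again a limit rather than a number. The measured step is therefore a step that the two limits leave unreadable from compound 1 to compound 2.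

Compound 3 is `CCC(=O)N[C@@H]1CCCc2c1cncc2N1Cc2cc(Cl)ccc2C1=O`; the difference between its core and the core of compound 1 is not broken down here. In this assay compound 3 gives < 3.5 mL/min/kg, once more a limit and not a number. All three results share (the limit of < 3.5 mL/min/kg in this assay, at which 3 of the 3 values shown sit), so no ordering among them can be read.

The unmeasured compound 4 is `CS(=O)(=O)N[C@@H]1CCCc2c1cncc2N1Cc2cc(Cl)ccc2C1=O`. It differs from compound 3 by methylsulfonyl in place of propanoyl on an amine nitrogen, which is the same change as that from compound 1 to compound 2, at a place described in identical words. The step from compound 3 to compound 4 is expected to be a step that the limit leaves unreadable from compound 3 to compound 4, resting on compound 1 and compound 2 sitting together at the limit of < 3.5 mL/min/kg in this assay, at which 3 of the 3 values shown sit, and on compound 3 giving < 3.5 mL/min/kg. Compound 4 is accordingly estimated at 2.5 mL/min/kg, with a range from 1 mL/min/kg to 5 mL/min/kg, most likely reported only as a limit.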

Compound 4, clearance: < 3.5 mL/min/kg
Compound 4 was reported as a limit; the forecaster's own chance of this, stated with the estimate: 80%; the middle value does not contradict the limit.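

In this assay compound 4 gives < 3.5 mL/min/kg, which is a limit of the assay and not a number. No step can therefore be read between compound 3 and compound 4, as every result shares one limit: the limit of < 3.5 mL/min/kg in this assay, at which 4 of the 4 values shown sit.

The compounds shown leave open how the clearance values of all four compare, and whether methylsulfonyl in place of propanoyl on an amine nitrogen alters clearance at all.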